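This account rests on a few compounds, and the source may have more. Where it says the series, first, only, none or still open, it means among the compounds named here.

Of the compounds shown here, three have so far been tested in a functional assay on MDA-MB-231 cells (Homo sapiens) for cytotoxicity, read by MTT assay, with a stated time of 72 h; on this read-out lower numbers stand for stronger inhibition and higher numbers for weaker inhibition. Compound 1 `CN(C)CCNc1nc(-c2ccc(NC(=O)Nc3ccccc3)cc2)nc2ccsc12` gives 1310 nM in this assay. Compound 2 `CN(C)CCNc1nc(-c2ccc(NC(=O)Nc3ccccc3F)cc2)nc2ccsc12` carries the change (fluoro in place of hydrogen on an aromatic carbon), and in this assay compound 2 gives 600 nM, a step of a 2.2-fold lower number from compound 1 to compound 2 (0.34 log units; beyond the scatter). Compound 3 `CCN(CC)CCCNc1nc(-c2ccc(NC(=O)Nc3ccccc3)cc2)nc2ccsc12` keeps the unchanged urea end of compound 1 but alters the side chain, and in this assay compound 3 gives 1230 nM; the step of a 1.1-fold lower number from compound 1 to compound 3 (0.03 log units; within the scatter) means the two numbers cannot be told apart.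

Compound 4 `CCN(CC)CCCNc1nc(-c2ccc(NC(=O)Nc3ccc(F)cc3)cc2)nc2ccsc12` is not yet measured. It is related to compound 3 by fluoro in place of hydrogen on an aromatic carbon. This is the same kind of change that turns compound 1 into compound 2, and it appears in both of these pairs, but the place is not identical: in compound 2 the fluoro sits ortho to a large group, whereas in compound 4 it sits para to a large group. The cores of compound 3 and compound 1 differ by (diethylamino)methyl in place of dimethylamino on a saturated chain carbon, two bonds along the chain from a nitrogen on an aromatic ring.

Because the step of a 2.2-fold lower number from compound 1 to compound 2 (0.34 log units; beyond the scatter) was modest, compound 4 is expected to show a step of a 1.8-fold lower number from compound 3 to compound 4 (0.24 log units; within the scatter) in this assay, with some allowance for the different place of the fluoro. Compound 4 is therefore estimated at 700 nM, with a likely range from 300 nM to 1800 nM.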

Compound 4, half-maximal inhibitory concentration: 530 nM
Beside the measured number, compound 4's estimate is 1.3-fold (0.12 log units) above it; measured number inside the range.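

In this assay, putting a fluoro in place of a hydrogen on the terminal phenyl ring gives a 2.3-fold lower number from compound 3 to compound 4 (0.37 log units; beyond the scatter), and this step is about the same size as the one seen earlier on the other core: the same change on two cores in this assay, a 2.2-fold lower number (0.34 log units; beyond the scatter) from compound 1 to compound 2 and a 2.3-fold lower number (0.37 log units; beyond the scatter) from compound 3 to compound 4, 1.1-fold (0.03 log units) apart, within the scatter of two such steps Within these two pairs, then, the change carries over from one core to the other with its size intact, even though the side chains differ and the fluoro stands at a different place on the ring in each pair. Within the data shown here, this does not show a general rule, as it rests on only two pairs, and it does not explain why the numbers fall or separate the place of the fluoro from the difference between the cores, as each core appears here with the fluoro at one place only.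

Going by these compounds, it remains open whether a fluoro at one and the same place would give a matching step on both cores, and whether a chloro, methoxy or trifluoromethyl group on that ring would behave like the fluoro. Also open, on these data alone, is whether the step would hold with a longer chain or with a morpholine at the end of the side chain.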